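The source may report more compounds than this note shows. Statements on the series, on what has been measured and on what is new or still open speak of the compounds shown alone.

Measured compounds:
- compound 1 `Oc1ccc(-c2cc(-c3ccccn3)nc(-c3ccccc3Cl)c2)cc1`: "not determined" (no result reported) in a functional assay on HCT-15 cells (Homo sapiens) for cytotoxicity, read by CCK-8 assay and cell counting, with a stated time of 2 days; on this read-out lower numbers stand for stronger inhibition and higher numbers for weaker inhibition
- compound 2 `Oc1ccc(-c2cc(-c3ccccc3)nc(-c3ccccc3Cl)c2)cc1`: 4990 nM

In this assay, among the compounds with values here, compound 2 gives 4990 nM, and this is the only number in the set, since compound 1 carries no result. Within the data shown here, there is therefore no measured step against which compound 2 can be placed; it stands alone. Compound 3 `Oc1ccc(-c2cc(-c3cccs3)nc(-c3ccccc3Cl)c2)cc1` differs from compound 2 in one place: thiophen-2-yl in place of phenyl on an aromatic carbon, with the remainder of the shared core unchanged. Among the measured compounds shown here, no step between two measured compounds with this kind of exchange is available, so the expectation rests on the single value of compound 2. For compound 3 the estimated step from compound 2 is small and within the scatter, with no clear direction, giving a 1.2-fold lower number from compound 2 to compound 3 (0.10 log units; within the scatter). Compound 3 is thus expected to show about 4000 nM in this assay, within a range from 1500 nM to 12000 nM.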

Compound 3, half-maximal inhibitory concentration: 5430 nM
The estimate for compound 3 lay 1.4-fold (0.13 log units) below the measured number, within the range that was stated.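

In this assay, placing thiophen-2-yl instead of phenyl on this aromatic carbon next to the ring nitrogen gives a 1.1-fold higher number from compound 2 to compound 3 (0.04 log units; within the scatter) and so leaves compound 2 and compound 3 indistinguishable. Within the data shown here, this is the first measured step in the set, and it shows that on this read-out the five-membered aromatic ring with its sulfur atom and the six-membered all-carbon ring cannot be told apart at this position. Nothing available bears on why the two read alike.

On these data alone, what remains open is whether a group of a different kind on this carbon, such as an amine, a carboxylic acid or a longer alkyl chain, would shift the number beyond the scatter. The two compounds also leave open whether this insensitivity extends to the 2-chlorophenyl and 4-hydroxyphenyl positions.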